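The compounds below may be only part of what the source reports. "The series", "measured", "known", "first", "only" and "open" are said of these compounds alone.

Measured compounds:
compound 1, `COc1cc(C(=O)O)ccc1OCCCCOc1ccc(C(=O)CC(C)(C)C)c(O)c1C`, 109%
compound 2, `COc1cc(C(=O)O)ccc1OCCCCOc1ccc(C(=O)CC(C)C)c(O)c1C`, 73.9%
compound 3, `Cc1c(OCCCCOc2ccc(C(=O)O)cc2)ccc(C(=O)CC(C)C)c1C`, 16.6%

In an assay on HEK293 cells for positive allosteric modulation of metabotropic glutamate receptor 3 (Rattus norvegicus), read by thallium flux, with a stated time of 2.5 min (a higher number here means a larger maximal response, a lower number a smaller maximal response), compound 1 gives 109%, compound 2 gives 73.9% and compound 3 gives 16.6%. Compound 2 thus stands second highest of the three, between compound 1 and compound 3, with both gaps beyond the scatter. Among the measured compounds shown here, the one single-point step available, a number 35.1 percentage points lower from compound 1 to compound 2 (beyond the scatter), concerns the saturated chain on the ketone side of the core and says nothing about the aromatic ring that carries the carboxy group.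

Compound 4, `Cc1c(OCCCCOc2ccc(C(=O)O)cc2F)ccc(C(=O)CC(C)C)c1O`, differs from compound 2 by fluoro in place of methoxy on an aromatic carbon, on an aromatic carbon ortho to a large group and meta to the carboxy group. For the measured compounds named here, no measured step bears on this change. Compound 3, which also lacks the methoxy but differs from compound 2 in a second place as well, gives a far lower response, so the two values alone cannot be read as a single step. Going by the values given here, with no directly comparable step, the estimate for compound 4 is set somewhat below compound 2, with a wide range: 60%, between 30% and 95%. The expected step is a number 13.9 percentage points lower from compound 2 to compound 4 (beyond the scatter).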

Compound 4, largest response reached (reported as percent of maximum), in percent of the reference or control that the assay uses: 67.7%
Compound 4: middle estimate off by 7.7 percentage points, on the low side; the measured number falls inside the stated range.
By their numbers in this assay, from the lowest: compound 3; then compounds 4 and 2 (each within the scatter of the next); then compound 1.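

In this assay, fluoro in place of methoxy on an aromatic carbon gives a number 6.2 percentage points lower from compound 2 to compound 4 (within the scatter), so the two compounds cannot be told apart by this read-out. Among the compounds shown here, this is the first reading at this position, since the earlier single-place step concerned only the saturated chain, and it shows that within this pair the methoxy group, on an aromatic carbon ortho to a large group and meta to a carboxy group, is not needed for a maximal response of this size: the single fluorine atom serves as well, within the scatter. Nothing measured here explains why the two groups can be exchanged in this way.

As far as these compounds go, whether the position accepts other groups as readily remains open, for instance a bare hydrogen, chloro, nitrile or a longer ethoxy group, and so does whether the exchange holds with the saturated chain of compound 1. Compound 3 gives 16.6% but differs from compound 4 in more than one place, so which of its differences accounts for that value also stays unresolved.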